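Replacing the Benzyl Amide of Compound 2 with a Chlorophenyl

The compounds below may be only part of what the source reports. "The series", "measured", "known", "first", "only" and "open" are said of these compounds alone.

Of the compounds shown here, two have been measured. Within the data shown here, in a functional assay on HeLa cells (Homo sapiens) for cytotoxicity, read by MTT assay, with a stated time of 48 h (a higher number here means a weaker inhibitor, a lower number a stronger inhibitor), compound 1 `COc1cc([C@@H]2C[C@@]2(CO)C(=O)Nc2ccccc2)cc(OC)c1OC` gives 86400 nM, and compound 2 `COc1cc([C@@H]2C[C@@]2(CO)C(=O)NCc2ccc(C)cc2)cc(OC)c1OC` gives 41200 nM, the lowest of the two numbers; the only step recorded, a 2.1-fold lower number from compound 1 to compound 2 (0.32 log units; beyond the scatter), goes with 4-methylbenzyl in place of phenyl on an amide-type nitrogen. Compound 3 `COc1cc([C@@H]2C[C@@]2(CO)C(=O)Nc2ccccc2Cl)cc(OC)c1OC` differs from compound 2 by 2-chlorophenyl in place of 4-methylbenzyl on an amide-type nitrogen, which largely returns toward the phenyl amide of compound 1, so a modest move back toward a higher number is expected, as a 1.7-fold higher number from compound 2 to compound 3 (0.23 log units; within the scatter). Compound 3 is therefore estimated at 70000 nM, within 30000 nM to 160000 nM.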

Compound 3, half-maximal inhibitory concentration: 13300 nM
Estimate against measurement, compound 3: 5.3-fold (0.72 log units) above; the measured number lies below the stated range.
By their numbers in this assay, from the lowest: compound 3; then compound 2; then compound 1.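

In this assay, a phenyl group on the amide-type nitrogen need not be the weaker choice: 2-chlorophenyl in place of 4-methylbenzyl gives a 3.1-fold lower number from compound 2 to compound 3 (0.49 log units; beyond the scatter). A single chloro in place of hydrogen on an aromatic carbon gives a 6.5-fold lower number from compound 1 to compound 3 (0.81 log units; beyond the scatter), so this one ring change alone reverses the order that compound 1 and compound 2 had suggested. No evidence is available to explain this shift.

The compounds shown leave open whether 4-chlorophenyl or 2-methoxyphenyl would match 2-chlorophenyl, and whether 2-chlorobenzyl would bring the same gain to the benzyl amides.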